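The source may hold more compounds than are shown below. What is called first, only, known or untested is meant among the compounds shown, and "the series" means these compounds.

Compound 1 `COc1cc(OC)c(OC)cc1/C=C/C(=O)c1ccc(O)cc1` gives 2.5 ug/mL in a functional assay, read by Griess assay, with a stated time of 2.5 h; a lower number here means a stronger inhibitor, a higher number a weaker inhibitor.
Compound 2 `COc1cc(OC)c(OC)cc1/C=C/C(=O)c1ccccc1` gives 2.01 ug/mL in this assay.
Compound 3 `COc1cc(OC)c(OC)cc1/C=C/C(=O)c1ccc(Cl)cc1` gives 2.01 ug/mL in this assay.

Compound 3 stands level with compound 2 at the digits shown, and the two together hold the lowest numbers of the three; the step of no change at the digits printed from compound 2 to compound 3 (within the scatter), and the step of a 1.2-fold lower number from compound 1 to compound 3 (0.09 log units; within the scatter). All three compounds share the same core and differ only in the group on one aromatic carbon of the ring bearing the carbonyl.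

Compound 4 `COc1cc(OC)c(OC)cc1/C=C/C(=O)c1ccc(Br)cc1` has not yet been measured in this assay. It differs from compound 3 by bromo in place of chloro on an aromatic carbon. Within the data shown here, no measured step involves bromo. Among the measured compounds shown here, the steps that bear on it are those that change the group at the same carbon: a 1.2-fold lower number from compound 1 to compound 2 (0.09 log units; within the scatter), a 1.2-fold lower number from compound 1 to compound 3 (0.09 log units; within the scatter) and no change at the digits printed from compound 2 to compound 3 (within the scatter), every one of them within the scatter. Hydroxy, hydrogen and chloro at this carbon thus leave the number essentially unchanged, and no step beyond the scatter is expected for bromo either; the expected step is a 1.0-fold lower number from compound 3 to compound 4 (0.00 log units; within the scatter). Compound 4 is therefore estimated at 2 ug/mL, within a range from 1.2 ug/mL to 3.5 ug/mL.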

Compound 4, half-maximal inhibitory concentration: 2.22 ug/mL
Compound 4: middle estimate off by 1.1-fold (0.05 log units), on the low side; the measured number falls inside the stated range.
By their numbers in this assay, from the lowest: compounds 2, 3, 4 and 1 (each within the scatter of the next).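

In this assay, the exchange of one halogen for another at this carbon, 4-chlorophenyl to 4-bromophenyl, gives a step that stays small (a 1.1-fold higher number from compound 3 to compound 4 (0.04 log units; within the scatter)). Bromo also stays close to the other two groups (a 1.1-fold higher number from compound 2 to compound 4 (0.04 log units; within the scatter); a 1.1-fold lower number from compound 1 to compound 4 (0.05 log units; within the scatter)), so a fourth group, and a second halogen, adds no separation: hydroxy, hydrogen, chloro and bromo at this carbon, para to a large group, all read alike across compounds 1 to 4. Nothing available here explains this flat reading.

From the compounds shown here alone, whether an amine, a carboxylic acid or a longer chain at this carbon would move the number beyond the scatter remains open. So does whether this assay responds to changes elsewhere on the shared core.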